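Nitro removal on the sulfonyl aryl across two cores

The compounds below may be only part of what the source reports. "The series", "measured", "known", "first", "only" and "open" are said of these compounds alone.

Three compounds are measured in a functional assay for inhibition, read by spectrophotometry, with a stated time of 20 min, tested at 5 mg/mL; on this read-out higher numbers stand for a stronger effect at the one concentration tested and lower numbers for a weaker effect. Compound 1 `CCC(C)C(C(=O)Nc1ccc(C(C)=O)cc1)N(C(=O)c1ccccc1)S(=O)(=O)c1ccc([N+](=O)[O-])cc1` gives 53.2% in this assay. Going by the values given here, compound 3 `CCC(C)C(C(=O)Nc1ccc(C(C)=O)cc1)N(C(=O)c1ccccc1)S(=O)(=O)c1ccccc1` differs from it by hydrogen in place of nitro on an aromatic carbon and gives 16.8%; the step of a number 36.4 percentage points lower from compound 1 to compound 3 (beyond the scatter) is the only one-place change measured so far. Among the compounds with values here, compound 2 `CC(=O)c1ccc(NC(=O)C2CC(O)CN2S(=O)(=O)c2ccc([N+](=O)[O-])cc2)cc1` gives 70.7%, the highest of the three; the difference between the core of compound 2 and the core of compound 1 is not broken down here, and the two values show only that compound 2 stands above compound 1 by more than the scatter.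

Compound 4 `CC(=O)c1ccc(NC(=O)C2CC(O)CN2S(=O)(=O)c2ccccc2)cc1` is not yet measured. It differs from compound 2 by hydrogen in place of nitro on an aromatic carbon, at a place described in the same words as for the change from compound 1 to compound 3, so this is the same change on a different core. In this assay the expected step is a number 34.7 percentage points lower from compound 2 to compound 4 (beyond the scatter), because the same change gave a number 36.4 percentage points lower from compound 1 to compound 3 (beyond the scatter) on the core of compound 1. On these data alone, whether the core of compound 2 carries the change to the same extent is unknown, so the range is kept wide. Compound 4 is therefore estimated at 36% in this assay, expected to lie between 14% and 58%.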

Compound 4, a percentage reported as inhibition, at one concentration (the size of the read-out at that concentration, not a potency): 58.7%
For compound 4 the middle estimate is 22.7 percentage points below the measured one; measured number above the stated range.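

In this assay, going from 4-nitrophenyl to phenyl on the core of compound 2 gives a number 12 percentage points lower from compound 2 to compound 4 (beyond the scatter), so the step keeps the direction seen on the core of compound 1. The direction carries over between these two cores, but the size does not: the same change on two cores in this assay, a number 36.4 percentage points lower (beyond the scatter) from compound 1 to compound 3 and a number 12 percentage points lower (beyond the scatter) from compound 2 to compound 4, 24.4 percentage points apart, beyond the scatter of two such steps

Going by these compounds alone, with a single pair on each core, this shows only that a step measured on one core cannot be moved to the other at its full size; it does not show which part of the cores sets the size, nor what a further core would give.

The compounds shown carry only nitro or hydrogen at this place on the aromatic ring, so it remains open how an amine, a carboxylic acid or a nitrile there would read on either core, and whether such groups would also show different step sizes on the two cores. Also open, on these data alone, is whether a third core would give a step close to one of these two or a different one, and so whether either step is the more typical for the series.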